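The compounds below may be only part of what the source reports. "The series", "measured", "known", "first", "only" and "open" are said of these compounds alone.

Compound 2 `COc1cc(/C=C2\Cc3ccccc3/C(=C\c3ccc([N+](=O)[O-])cc3)C2=O)ccc1O` gives 5800 nM in a functional assay on HSG cells (Homo sapiens) for cytotoxicity (on this read-out lower numbers stand for higher toxicity in this test and higher numbers for lower toxicity in this test), and among the two plain numbers this is the lower one. Among the compounds with values here, its closest neighbour is compound 1 `O=C1/C(=C/c2ccc(O)cc2)Cc2ccccc2/C1=C\c1ccc([N+](=O)[O-])cc1`, which gives 11000 nM in this assay; the step of a 1.9-fold lower number from compound 1 to compound 2 (0.28 log units; within the scatter) is the only single-point comparison available, and it lies within the scatter. Compound 3 `COc1ccc(/C=C2\CC/C(=C\c3ccc([N+](=O)[O-])cc3)C2=O)cc1` is reported in this assay only as > 400000 nM, which is a limit of the assay rather than a number (the limit of > 400000 nM in this assay, at which 1 of the 3 values shown sits).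

Compound 4 `COc1ccc(/C=C2\Cc3ccccc3/C(=C\c3ccc([N+](=O)[O-])cc3)C2=O)cc1OC` is compound 2 changed in one place: methyl in place of hydrogen on an oxygen on an aromatic ring. Within the data shown here, the one measured step, from compound 1 to compound 2, also touches the oxygen substituents on this ring and moved the number by less than the scatter, so for compound 4 the expected step of a 1.2-fold higher number from compound 2 to compound 4 (0.08 log units; within the scatter) is likewise small, with no clear direction. Compound 4 is therefore expected to give about 7000 nM in this assay, within a range of 2500 nM to 25000 nM.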

Compound 4, half-maximal cytotoxic concentration: 4400 nM
For compound 4 the middle estimate is 1.6-fold (0.20 log units) above the measured one, within the range that was stated.
By their numbers in this assay, from the lowest: compounds 4, 2 and 1 (each within the scatter of the next, the first and the last beyond it). At a limit, above all of these: compound 3.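

In this assay, replacing the hydroxy group with methoxy gives a 1.3-fold lower number from compound 2 to compound 4 (0.12 log units; within the scatter), so at this oxygen on the aromatic ring, a free hydroxy group is not needed for cytotoxicity at this level. The larger change from 4-hydroxyphenyl to 3,4-dimethoxyphenyl gives a 2.5-fold lower number from compound 1 to compound 4 (0.40 log units; beyond the scatter), a modest step and the first here to clear the scatter, although neither of the two single changes along that route does so alone. Nothing measured here gives a reason for these shifts.

The compounds shown leave open whether an ethyl group or a longer chain on this oxygen, or an amine or a carboxylic acid on the ring, would keep the number in this range. As far as these compounds go, compound 3 is known only through a limit, > 400000 nM, so the effect of this change on its core also stays open.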